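Phenyl in Place of Oxazolyl: An Expected Tolerability Reading

This account rests on a few compounds, and the source may have more. Where it says the series, first, only, none or still open, it means among the compounds named here.

Among the compounds with values here, compound 1, `O=C1CC(c2cnco2)CN1c1cnn2c1CN(C(=O)Nc1cc(F)c(F)c(F)c1)C(C1CC1)C2`, is the only member of this small set with a full number in a toxicity assay on HepG2 2.2.15 cells (Homo sapiens) for cytotoxicity, read by CellTiter-Glo; a lower number here means that less compound is tolerated, a higher number that more compound is tolerated: compound 1 gives 139000 nM. Compound 2, `C[C@H]1Cn2ncc(N3CC(c4ccccc4)CC3=O)c2CN1CC(=O)Nc1cc(F)c(F)c(F)c1`, is reported in this assay only as a limit of the assay, > 2000 nM. That reading is the limit named in the limit of > 2000 nM in this assay, at which 1 of the 2 values shown sits. Within the data shown here, the two measured compounds do not differ in a single place, so no measured step between them can be drawn. Compound 3, `O=C1CC(c2ccccc2)CN1c1cnn2c1CN(C(=O)Nc1cc(F)c(F)c(F)c1)C(C1CC1)C2`, is not yet measured; it is compound 1 with phenyl in place of 1,3-oxazol-5-yl on a saturated ring carbon. Seen one bond further out, the change reads 4-(1,3-oxazol-5-yl)-2-oxopyrrolidin-1-yl to 2-oxo-4-phenylpyrrolidin-1-yl, and the rest of the shared core is untouched. Among the measured compounds shown here, with no measured step to lean on, the account expects the step of a 1.4-fold lower number from compound 1 to compound 3 (0.14 log units; within the scatter) to be small, if anything a slight move towards less tolerance, and not clearly beyond the usual scatter. Compound 3 is therefore estimated at 100000 nM, with a range from 40000 nM to 200000 nM.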

Compound 3, half-maximal cytotoxic concentration: 12800 nM
Compound 3: middle estimate off by 7.8-fold (0.89 log units), on the high side, and the stated range ends above it.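

In this assay, within the data shown here, phenyl in place of 1,3-oxazol-5-yl gives the first measured step in this set, an 11-fold lower number from compound 1 to compound 3 (1.04 log units; beyond the scatter), so this saturated ring carbon of the five-membered non-aromatic ring with 1 nitrogen is a place where the choice of group matters to the reading. With the rest of the shared core untouched, replacing a five-membered aromatic ring with 2 hetero atoms by a six-membered aromatic ring of carbon only is enough on its own to move the number beyond the usual scatter, towards less compound being tolerated. Nothing measured in this set bears on why the number falls at this change.

As far as these compounds go, whether other groups on this ring carbon would read like phenyl or like 1,3-oxazol-5-yl stays open, and a pyridin-3-yl ring or a dimethylamino group there would begin to test it. Compound 2, which also carries phenyl, gives > 2000 nM, a limit of the assay and not a number, and it differs from compound 3 in more than one place, so it leaves open how this change reads on another core.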